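The source may hold more compounds than are shown below. What is called first, only, known or untested is meant among the compounds shown, and "the series" means these compounds.

Compound 1, `O=C(Nc1ccc(-c2noc(-c3cccc(NS(=O)(=O)c4cccc(Cl)c4)c3)n2)c(Cl)c1)c1cccnc1`, gives > 10000 nM in a functional assay on MDA-MB-231 cells (Homo sapiens) for antiproliferative activity, read by MTT assay, with a stated time of 72 h; a lower number here means a stronger inhibitor, a higher number a weaker inhibitor; this is a limit of the assay, not a number.
Compound 2, `COc1cccc(S(=O)(=O)Nc2cccc(-c3nc(-c4ccc(NC(=O)c5cccnc5)cc4Cl)no3)c2)c1`, gives > 10000 nM; this too is a limit.
Compound 3, `Cc1ccc(NC(=O)Nc2cccc(-c3nc(-c4ccc(NC(=O)c5cccnc5)cc4Cl)no3)c2)cc1`, gives 3500 nM.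

For the measured compounds named here, compound 3 thus stands as the only compound with a number; the other two values sit at the limit of > 10000 nM in this assay, at which 2 of the 3 values shown sit. Compound 4, `COc1ccc(NC(=O)Nc2cccc(-c3nc(-c4ccc(NC(=O)c5cccnc5)cc4Cl)no3)c2)cc1C(F)(F)F`, differs from compound 3 by 4-methoxy-3-(trifluoromethyl)phenyl in place of 4-methylphenyl on an amide-type nitrogen. Going by the values given here, the measured steps reaching compound 3, an at least 2.8-fold lower number from compound 1 to compound 3 (0.45 log units; beyond the scatter) and an at least 2.8-fold lower number from compound 2 to compound 3 (0.45 log units; beyond the scatter), both exchange a sulfonyl group for the (4-methylphenyl)carbamoyl group; neither alters the phenyl on the carbamoyl nitrogen, so no measured step bears directly on the change to compound 4. The expected step from compound 3 to compound 4 is a 1.3-fold lower number from compound 3 to compound 4 (0.10 log units; within the scatter), within the scatter. Compound 4 is expected to give 2800 nM in this assay, between 900 nM and 9000 nM.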

Compound 4, half-maximal inhibitory concentration: 1700 nM
Estimate against measurement, compound 4: 1.6-fold (0.22 log units) above; the measured number falls inside the stated range.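

In this assay, for the compounds shown here, 4-methoxy-3-(trifluoromethyl)phenyl in place of 4-methylphenyl on the amide-type nitrogen gives a 2.1-fold lower number from compound 3 to compound 4 (0.31 log units; beyond the scatter), the only measured step at this position, since the earlier steps exchanged a whole sulfonyl group. The position therefore responds to a change of substituents on this phenyl ring, and the larger group, which adds a hydrogen-bond acceptor, does not cost activity. Nothing shown here gives a reason for the step.

The compounds shown do not separate the methoxy from the trifluoromethyl in this step. They also leave open how an amine or a carboxylic acid on this phenyl ring would fare.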